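The source may hold more compounds than are shown below. What is called first, only, known or untested is meant among the compounds shown, and "the series" means these compounds.

Compound 1, `COc1ccc2nc(C(=O)Nc3ccc(-c4ccccc4)cc3)c(C)c(O)c2c1`, in a functional assay on Hep 3B2 cells (Homo sapiens) for antiproliferative activity, read by MTT assay, with a stated time of 24 h, tested at 0.01 ug/mL (a higher number here means a stronger effect of the compound at the concentration tested, a lower number a weaker effect), gives 0.35%.
Compound 2, `Cc1c(C(=O)Nc2ccc(-c3ccccc3)cc2)nc2ccccc2c1O`, in this assay gives 0.23%.
Compound 3, `COc1ccc2nc(C(=O)Nc3ccc(-c4ccccc4)cc3)c(C)c(C(=O)O)c2c1`, in this assay gives -0.12%.

All three numbers sit close to zero, so none of these compounds shows a noticeable effect at the concentration tested. Compound 3 has the lowest of the three numbers, but its nearest neighbour, compound 2, and its furthest, compound 1, are both within the usual scatter of it, so no ordering can be read from them.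

Compound 4, `Cc1c(C(=O)Nc2ccc(-c3ccccc3)cc2)nc2ccccc2c1C(=O)O`, differs from compound 3 in one place: hydrogen in place of methoxy on an aromatic carbon. The same change has been seen once before, on the way from compound 1 to compound 2, where a number 0.1 percentage points lower from compound 1 to compound 2 (within the scatter). That step stayed within the scatter, so for compound 4 no movement beyond the scatter is expected in this assay, and the estimated step is a number 0.1 percentage points lower from compound 3 to compound 4 (within the scatter). The expected value for compound 4 is -0.2%, with a range from -4% to 4%.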

Compound 4, a percentage reported as inhibition, at one concentration (the size of the read-out at that concentration, not a potency): -0.68%
Compound 4: middle estimate off by 0.5 percentage points, on the high side; the measured number falls inside the stated range.
By their numbers in this assay, from the lowest: compounds 4, 3, 2 and 1 (each within the scatter of the next).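

With hydrogen in place of methoxy on an aromatic carbon, the read-out shows a number 0.6 percentage points lower from compound 3 to compound 4 (within the scatter), so this swap has now been seen with a carboxy group on the core as well as with a hydroxy group: the same change on two cores in this assay, a number 0.1 percentage points lower (within the scatter) from compound 1 to compound 2 and a number 0.6 percentage points lower (within the scatter) from compound 3 to compound 4, 0.4 percentage points apart, within the scatter of two such steps

Carboxy in place of hydroxy shows a number 0.9 percentage points lower from compound 2 to compound 4 (within the scatter), so that swap has now been seen both with and without the methoxy group: the same change on two cores in this assay, a number 0.5 percentage points lower (within the scatter) from compound 1 to compound 3 and a number 0.9 percentage points lower (within the scatter) from compound 2 to compound 4, 0.4 percentage points apart, within the scatter of two such steps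

Neither change has therefore moved the number beyond the scatter on either core, though all four numbers sit close to zero at the one concentration tested.

The compounds shown leave open whether an amine or a longer chain on that aromatic carbon would give a number beyond the scatter. They also leave open how these four compounds would read at a higher concentration.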